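Carboxymethoxy to (carboxymethyl)sulfonyl on the chain of compound 2

The source may report more compounds than this note shows. Statements on the series, on what has been measured and on what is new or still open speak of the compounds shown alone.

Measured in a functional assay for inhibition, with Homo sapiens as the target; on this read-out lower numbers stand for stronger inhibition and higher numbers for weaker inhibition:
compound 1 `O=C(O)CCCCCn1nc(-c2ccccc2)c(-c2ccccc2)c1-c1ccccc1`: > 78000 nM (a limit)
compound 2 `O=C(O)COCCCCCCn1nc(-c2ccccc2)c(-c2ccccc2)c1-c1ccccc1`: 440 nM

Within the data shown here, compound 2 holds the only actual number so far, since the other value is a limit. Compound 3 `O=C(O)CS(=O)(=O)CCCCCCn1nc(-c2ccccc2)c(-c2ccccc2)c1-c1ccccc1` replaces carboxymethoxy with (carboxymethyl)sulfonyl: (carboxymethyl)sulfonyl in place of carboxymethoxy on a saturated chain carbon, six bonds along the chain from an aromatic nitrogen. Among the measured compounds shown here, the one measured step, an at least 170-fold lower number from compound 1 to compound 2 (2.24 log units; beyond the scatter), was large and also lay in this chain, but it does not test this exchange. A moderate move towards a higher number is expected, with the estimated step being a 4.5-fold higher number from compound 2 to compound 3 (0.66 log units; beyond the scatter). The estimate for compound 3 is 2000 nM, with an expected range of 450 nM to 10000 nM.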

Compound 3, half-maximal inhibitory concentration: 22000 nM
Compound 3: middle estimate off by 11-fold (1.04 log units), on the low side, outside the stated range (above it).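

In this assay, exchanging carboxymethoxy for (carboxymethyl)sulfonyl, six bonds along the chain from an aromatic nitrogen, gives a 50-fold higher number from compound 2 to compound 3 (1.70 log units; beyond the scatter), so this position responds strongly even with the carboxylic acid retained. The sulfonyl chain still keeps part of the gain, with an at least 3.5-fold lower number from compound 1 to compound 3 (0.54 log units; beyond the scatter). That step is only a bound because compound 1 is a limit, not a number: the limit of > 78000 nM in this assay, at which 1 of the 3 values shown sits.

Open, on these data alone, is whether a thioether or sulfoxide in the same place would sit nearer compound 2 or compound 3. Also open, as far as these compounds go, is how a longer chain would read with either group.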